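Phenyl to Isopropyl on the Core of Compound 3

The compounds below may be only part of what the source reports. "The series", "measured", "known", "first", "only" and "open" are said of these compounds alone.

Of the compounds shown here, three have so far been measured in a functional assay on MOLT-4 cells (Homo sapiens) for inhibition; on this read-out higher numbers stand for weaker inhibition and lower numbers for stronger inhibition. Compound 1 `CCC(C)C(NC(=O)n1nnc2ccccc21)C(=O)NC(c1ccccc1)c1ccccc1` gives 79000 nM in this assay, and compound 2 `CCC(C)C(NC(=O)NO)C(=O)NC1CCCCC1` gives 150000 nM, a value that lies beyond the usual scatter of the first and stands for weaker inhibition. Compound 3 `O=C1NC(c2ccccc2)C(=O)N1C1CCCC1` returned no number in this assay but only a limit, > 200000 nM. Compound 3 therefore stands at the limit of > 200000 nM in this assay, at which 1 of the 3 values shown sits, the one position among the three that is not resolved as a number.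

Compound 4 `CC(C)C1NC(=O)N(C2CCCC2)C1=O` is not yet measured. Its structure differs from that of compound 3 in one respect: isopropyl in place of phenyl on a saturated ring carbon. Going by the values given here, no measured pair in this set differs in a single place, so the size of such a step cannot be read from the measured compounds. With compound 3 sitting at a limit, any step toward weaker inhibition would stay hidden, and only a step toward stronger inhibition of some size could be seen. The expectation is that compound 4 remains a weak inhibitor, with an estimated value of 200000 nM in this assay, in a range from 70000 nM to 600000 nM. The step of a number no higher from compound 3 to compound 4 (the limit leaves the size open) is thus expected to be none beyond the scatter, and a limit rather than a number is the more likely outcome for compound 4.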

Compound 4, half-maximal inhibitory concentration: > 200000 nM
Compound 4: no number, only a limit (the forecaster's own chance of this, stated with the estimate: 70%); the middle value sits exactly at the limit.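

In this assay compound 4 returned only a limit, > 200000 nM. Going by these compounds alone, compound 3 also stands at a limit, so no step between compound 3 and compound 4 can be read. The compounds shown leave open how isopropyl in place of phenyl on a saturated ring carbon alters inhibition in this assay: the limit of > 200000 nM in this assay, at which 2 of the 4 values shown sit.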